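The compounds below may be only part of what the source reports. "The series", "measured", "known", "first", "only" and "open" are said of these compounds alone.

Two compounds have been measured so far:
Compound 1 `COc1cc(-c2nn(-c3cccc(NC(=O)c4cccc(C(F)(F)F)c4)c3)cc2-c2ccncc2)ccc1Cl` gives 27900 nM in a functional assay on UACC-257 cells (Homo sapiens) for inhibition, read by sulforhodamine B assay, with a stated time of 48 h; a higher number here means a weaker inhibitor of growth, a lower number a stronger inhibitor of growth.
Compound 2 `COc1cc(-c2nn(-c3cccc(NC(=O)Nc4ccc(Cl)c(C(F)(F)F)c4)c3)cc2-c2ccncc2)ccc1Cl` gives 1210 nM in this assay.

Compound 2 holds the lower of these two numbers, and the only step shown between them is a 23-fold lower number from compound 1 to compound 2 (1.36 log units; beyond the scatter), a large one. Compound 3 `COc1cc(-c2nn(-c3cccc(NC(=O)c4ccccc4)c3)cc2-c2ccncc2)ccc1Cl` is not yet measured; it differs from compound 2 by phenyl in place of (4-chloro-3-(trifluoromethyl)phenyl)amino on a carbonyl carbon. That single measured step bears directly on this change, since it went the other way: adding the amino link and the chloro-bearing, trifluoromethyl-bearing ring gave a much lower number. Compound 3 removes that amino link again and also lacks the trifluoromethyl that compound 1 carries on its ring, so a large upward step in this assay is expected, landing near or somewhat above compound 1, because compound 1 gave 27900 nM. Compound 3 is estimated at 35000 nM, with a range from 9000 nM to 130000 nM. The expected step is therefore a 29-fold higher number from compound 2 to compound 3 (1.46 log units; beyond the scatter).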

Compound 3, concentration for 50% growth inhibition: 859 nM
Estimate against measurement, compound 3: 41-fold (1.61 log units) above; measured number below the stated range.
By their numbers in this assay, from the lowest: compounds 3 and 2 (each within the scatter of the next); then compound 1.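

In this assay, among the compounds shown here, a 32-fold lower number from compound 1 to compound 3 (1.51 log units; beyond the scatter), and the only change is hydrogen in place of trifluoromethyl on an aromatic carbon, so the high number of compound 1 goes with that single group rather than with the absence of the amino link. The plain phenyl on the carbonyl carbon also does as well as the larger (4-chloro-3-(trifluoromethyl)phenyl)amino, with a 1.4-fold lower number from compound 2 to compound 3 (0.15 log units; within the scatter), so neither the amino link nor the substituted ring is needed to reach a number of this size. Nothing measured here explains why trifluoromethyl has this effect.

On these data alone, it remains open whether a fluorine or a methyl on that same aromatic carbon would raise the number as trifluoromethyl does. As far as these compounds go, it is also open whether an unsubstituted phenylamino on the carbonyl carbon would give a number like that of compound 3.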